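The source may hold more compounds than are shown below. What is called first, only, known or untested is meant among the compounds shown, and "the series" means these compounds.

Among the compounds with values here, compound 2 `CCCCOC1CCN(c2nc(C(F)(F)F)ccc2CNC(=O)C(C)c2ccc(NS(C)(=O)=O)c(F)c2)CC1` is one of two compounds measured in a functional assay on CHO-K1 cells for antagonist activity at transient receptor potential cation channel subfamily V member 1 (Homo sapiens), read by FLIPR; a lower number here means a stronger inhibitor, a higher number a weaker inhibitor; there compound 2 gives 28.2 nM, the higher of the two numbers. The other, compound 1 `CC(C(=O)NCc1ccc(C(F)(F)F)nc1N1CCC(c2ccccc2)CC1)c1ccc(NS(C)(=O)=O)c(F)c1`, gives 25 nM in this assay. The two differ only in what sits on a saturated ring carbon, butoxy in compound 2 in place of phenyl in compound 1, and the step of a 1.1-fold higher number from compound 1 to compound 2 (0.05 log units; within the scatter) lies within the scatter of repeated measurements.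

Compound 3 `CC(C(=O)NCc1ccc(C(F)(F)F)nc1N1CCC(OC(=O)C(C)(C)C)CC1)c1ccc(NS(C)(=O)=O)c(F)c1` has not yet been measured. It differs from compound 2 by (tert-butyl)carbonyl in place of butyl on an oxygen on a saturated carbon, so that the butoxy group of compound 2 becomes a ((tert-butyl)carbonyl)oxy group in compound 3.

Within the data shown here, only one measured step bears on this part of the molecule, a 1.1-fold higher number from compound 1 to compound 2 (0.05 log units; within the scatter), and it shows that exchanging the group on that saturated ring carbon left the number within the scatter. Among the measured compounds shown here, no measured pair shows a carbonyl entering at this place, so what the added oxygen does here is unknown. The step of a 1.4-fold higher number from compound 2 to compound 3 (0.15 log units; within the scatter) is therefore expected to be small, leaning toward a higher number. Compound 3 is estimated at 40 nM in this assay, with a range from 12 nM to 130 nM.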

Compound 3, half-maximal inhibitory concentration: 45.2 nM
For compound 3 the middle estimate is 1.1-fold (0.05 log units) below the measured one; the range from low to high includes it.
By their numbers in this assay, from the lowest: compounds 1, 2 and 3 (each within the scatter of the next).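

In this assay, within the data shown here, the step of a 1.6-fold higher number from compound 2 to compound 3 (0.20 log units; within the scatter) is the first measured case of a carbonyl entering on the oxygen on a saturated carbon, and that step lies within the scatter. The step of a 1.8-fold higher number from compound 1 to compound 3 (0.26 log units; within the scatter) also lies within the scatter, so phenyl, butoxy and ((tert-butyl)carbonyl)oxy on the saturated ring carbon cannot be told apart in this assay, and none of the three compounds goes against that reading. There is no measurement here that explains why these different groups give values that cannot be separated.

Going by these compounds, it remains open whether an amine, a carboxylic acid or a much longer chain on that saturated ring carbon would also stay within the scatter of these three compounds, or would move the number clearly in either direction. All three compounds also share the rest of their structure, so they cannot show whether the same exchanges would give similar results on a different core.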